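Replacing the morpholine arm of compound 1 with an oxalate ester

The compounds below may be only part of what the source reports. "The series", "measured", "known", "first", "only" and "open" are said of these compounds alone.

Measured compounds:
compound 1 `N#CC1=C(NCC(=O)N2CCOCC2)N(c2ccccc2)C(=O)N2CCCCC(N3CCCC3)C12`: 73.5%
compound 2 `N#CC1=C(/N=C/Nc2ccccc2)N(c2ccccc2)C(=O)N2CCCCC(N3CCCC3)C12`: 79.3%
compound 3 `N#CC1=C(/N=C/c2ccc([N+](=O)[O-])cc2)N(c2ccccc2)C(=O)N2CCCCC(N3CCCC3)C12`: 91.7%

In a functional assay on the whole organism (strain albino) for inhibition, with Rattus norvegicus as the target, read by paw edema, with stated times of 1 h and 3 h, at a dose of 20 mmol/kg by the intraperitoneal route (on this read-out higher numbers stand for a stronger effect at the one dose given and lower numbers for a weaker effect), compound 1 gives 73.5%, the lowest of the three numbers. Its nearest neighbour is compound 2, since a number 5.8 percentage points higher from compound 1 to compound 2 (within the scatter); its furthest is compound 3, since a number 18.2 percentage points higher from compound 1 to compound 3 (beyond the scatter). Between the two imine compounds, a number 12.4 percentage points higher from compound 2 to compound 3 (beyond the scatter).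

Compound 4 `COC(=O)C(=O)NC1=C(C#N)C2C(N3CCCC3)CCCCN2C(=O)N1c1ccccc1` differs from compound 1 by (methoxycarbonyl)carbonyl in place of ((morpholin-4-yl)carbonyl)methyl on an amine nitrogen. Among the compounds with values here, no measured step makes this same change: the steps from compound 1 to compound 2 and to compound 3 each swap the whole aminoacetyl arm for an imine group, and only the larger of them went beyond the scatter. The amine nitrogen and its attachment to the shared core are kept in compound 4, so a step of the size seen for compound 3 has no direct support. The estimate for compound 4 is therefore a number 1.5 percentage points higher from compound 1 to compound 4 (within the scatter), that is, no change beyond the scatter, and compound 4 is expected to give 75%, in the range 62% to 88%.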

Compound 4, a percentage reported as inhibition, in the whole organism at one dose (the size of the read-out at that dose, not a potency): 88.3%
Estimate against measurement, compound 4: 13.3 percentage points below; the measured number lies above the stated range.
By their numbers in this assay, from the lowest: compounds 1, 2, 4 and 3 (each within the scatter of the next, the first and the last beyond it).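

In this assay, the amine nitrogen stays in place and the exchange of ((morpholin-4-yl)carbonyl)methyl for (methoxycarbonyl)carbonyl alone gives a number 14.8 percentage points higher from compound 1 to compound 4 (beyond the scatter), so among the compounds shown a step beyond the scatter from compound 1 no longer belongs to compound 3 and its imine alone. The ringless group of compound 4 stands level with both imine compounds, as a number 3.4 percentage points lower from compound 3 to compound 4 (within the scatter) and a number 9 percentage points higher from compound 2 to compound 4 (within the scatter) show, so neither the aromatic ring of those two compounds nor the morpholine ring is needed to reach this level. Nothing available gives a reason for the step.

The compounds shown do not tell which part of the entering group carries the step, as the morpholine ring, the arm and the ester all change together. On these data alone, whether a carboxylic acid, a primary amide or a plain acetyl group on the same amine nitrogen would hold this level remains open.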